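This account rests on a few compounds, and the source may have more. Where it says the series, first, only, none or still open, it means among the compounds named here.

Values in a functional assay on Ehrlich cells (Mus musculus) for cytotoxicity, read by trypan blue exclusion, with a stated time of 2 h, tested at 25 ug/mL (a higher number here means a stronger effect of the compound at the concentration tested, a lower number a weaker effect), for the three measured compounds:

compound 1, `N#CC1=C(NC(=O)c2ccccc2)N(c2ccc(S(N)(=O)=O)cc2)C2=C(C(=O)CCC2)C1c1ccc(Cl)cc1Cl`: 60%
compound 2, `COc1cc(C(=O)NC2=C(C#N)C(c3ccc(Cl)cc3Cl)C3=C(CCCC3=O)N2c2ccc(S(N)(=O)=O)cc2)cc(OC)c1OC`: 20%
compound 3, `CN(C)c1ccc(/C=N/C2=C(C#N)C(c3ccc(Cl)cc3Cl)C3=C(CCCC3=O)N2c2ccc(S(N)(=O)=O)cc2)cc1`: 30%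

Compound 3 stands second highest of the three numbers; its nearest neighbour is compound 2, whose value lies within the scatter of it, and its furthest is compound 1, which sits beyond the scatter above it.

Compound 4 is `CC(=O)CC(=O)NC1=C(C#N)C(c2ccc(Cl)cc2Cl)C2=C(CCCC2=O)N1c1ccc(S(N)(=O)=O)cc1`. The change from compound 3 is a group of 7 heavy atoms (4 carbon, 1 nitrogen, 2 oxygen; no ring) in place of a group of 11 heavy atoms (9 carbon, 2 nitrogen; one six-membered aromatic ring of carbon only), on a double-bonded ring carbon. The entering ((2-oxopropyl)carbonyl)amino carries no ring and brings one hydrogen-bond donor, while the leaving group has a six-membered aromatic ring of carbon only and no donor.

Going by the values given here, two measured steps bear on this position. The step of a number 30 percentage points lower from compound 1 to compound 3 (beyond the scatter) shows that exchanging an amide-bearing substituent for a ring-bearing imine cost activity in this assay. The step of a number 40 percentage points lower from compound 1 to compound 2 (beyond the scatter) shows that enlarging the aryl part of the amide cost even more. Compound 4 returns to an amide at this position, as in compound 1, but with no aromatic ring at all, a case not covered by any measured pair. Moving back towards the amide pattern of compound 1 suggests a rise, tempered by the absence of the ring; the expected step is a number 15 percentage points higher from compound 3 to compound 4 (beyond the scatter). Compound 4 is therefore estimated at 45%, with a range from 25% to 65%.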

Compound 4, a percentage reported as activity, at one concentration (the size of the read-out at that concentration, not a potency): 44%
For compound 4 the middle estimate is 1 percentage points above the measured one; low and high end bracket the measured number.
By their numbers in this assay, from the lowest: compounds 2 and 3 (each within the scatter of the next); then compound 4; then compound 1.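

In this assay, a group with no ring at this position on the double-bonded ring carbon can still carry activity: the ((2-oxopropyl)carbonyl)amino group in place of the ring-bearing imine gives a number 14 percentage points higher from compound 3 to compound 4 (beyond the scatter) and so sets an amide without an aromatic ring above the imine. With the amide kept, the group on the carbonyl carbon still matters in both directions, since 2-oxopropyl in place of 3,4,5-trimethoxyphenyl gives a number 24 percentage points higher from compound 2 to compound 4 (beyond the scatter) while 2-oxopropyl in place of phenyl gives a number 16 percentage points lower from compound 1 to compound 4 (beyond the scatter) and so falls short of the plain benzamide. The three amides therefore form an order with beyond-scatter gaps: phenyl first, 2-oxopropyl second, 3,4,5-trimethoxyphenyl last, which shows that the loss seen with the trimethoxyphenyl group is not simply a loss tied to leaving phenyl.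

Open, on these data alone, is how a methyl, a longer alkyl chain, a terminal carboxylic acid or a phenyl with a single methoxy group on this carbonyl carbon would fall within that order, and whether the ketone carbonyl of 2-oxopropyl contributes to the value of compound 4 at all. No measurement at hand gives a reason for any of these steps.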